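Replacing methoxy with chloro: what compound 4 may show

The compounds below may be only part of what the source reports. "The series", "measured", "known", "first", "only" and "open" are said of these compounds alone.

Compound 1 `O=C(/C=C/c1ccc(Br)cc1)c1cccc(-c2cccc(F)c2)c1`: 19800 nM
Compound 2 `O=C(/C=C/c1cccc(Br)c1)c1cccc(-c2cccc(F)c2)c1`: 9120 nM
Compound 3 `COc1ccc(/C=C/C(=O)c2cccc(-c3cccc(F)c3)c2)cc1`: 2440 nM

These three values come from a functional assay on A549 cells (Homo sapiens) for cytotoxicity, read by sulforhodamine B assay, with a stated time of 48 h; a lower number here means a stronger inhibitor, a higher number a weaker inhibitor. Compound 3 stands lowest of the three, with a 3.7-fold lower number from compound 2 to compound 3 (0.57 log units; beyond the scatter) and an 8.1-fold lower number from compound 1 to compound 3 (0.91 log units; beyond the scatter).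

Compound 4 `O=C(/C=C/c1ccc(Cl)cc1)c1cccc(-c2cccc(F)c2)c1` has not yet been measured. It differs from compound 3 in one place: chloro in place of methoxy on an aromatic carbon. This puts chloro in place of methoxy on an aromatic carbon, turning 4-methoxyphenyl into 4-chlorophenyl.

For the measured compounds named here, no chloro compound has a measured value, so the closest guide is compound 1, which carries 4-bromophenyl. Its step, an 8.1-fold lower number from compound 1 to compound 3 (0.91 log units; beyond the scatter), exchanges bromo for methoxy on the same aromatic carbon. The step of a 3.7-fold lower number from compound 2 to compound 3 (0.57 log units; beyond the scatter) is a weaker guide, since the bromo of compound 2 sits elsewhere, and a 2.2-fold lower number from compound 1 to compound 2 (0.34 log units; beyond the scatter) shows that this placement alters the number. Treating chloro like bromo is an assumption, and it points to a rise from compound 3, perhaps somewhat smaller than the drop seen from compound 1. The expected change is a 4.9-fold higher number from compound 3 to compound 4 (0.69 log units; beyond the scatter). For compound 4 the estimated value is 12000 nM, with an expected range from 5000 nM to 28000 nM.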

Compound 4, half-maximal inhibitory concentration: 15400 nM
Estimate against measurement, compound 4: 1.3-fold (0.11 log units) below; the range from low to high includes it.
By their numbers in this assay, from the lowest: compound 3; then compounds 2, 4 and 1 (each within the scatter of the next, the first and the last beyond it).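

The chloro compound shows that the low number of compound 3 in this assay is not specific to the comparison with bromo: a 6.3-fold higher number from compound 3 to compound 4 (0.80 log units; beyond the scatter) places methoxy apart from a second halogen on the same aromatic carbon, para to a large group. With a 1.3-fold lower number from compound 1 to compound 4 (0.11 log units; within the scatter) chloro and bromo cannot be told apart at this place, which turns what had been an assumption into a measured result for this pair. The step of a 1.7-fold higher number from compound 2 to compound 4 (0.23 log units; within the scatter) also lies within the scatter, so 4-chlorophenyl cannot be separated from 3-bromophenyl, even though a 2.2-fold lower number from compound 1 to compound 2 (0.34 log units; beyond the scatter) does separate the two bromo placements.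

Nothing given here accounts for the gap between methoxy and the two halogens. As far as these compounds go, it remains open whether the lower number belongs to methoxy alone or would also come with another group at this place, such as a hydroxyl, an ethoxy or an amine, and whether methoxy would keep its lead in the placement of the bromo of compound 2.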